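Sulfonyl aryl swap on a quinolinone core

The source may report more compounds than this note shows. Statements on the series, on what has been measured and on what is new or still open speak of the compounds shown alone.

Measured so far:
- compound 1 `COc1ccc(-c2cc(=O)c3c(OC)cc(OC)cc3n2Cc2ccccc2)cc1`: > 34400 nM in a functional assay on SUP-B15 cells (Homo sapiens) for antiproliferative activity, with a stated time of 72 h; on this read-out higher numbers stand for an effect only at larger amounts of compound and lower numbers for an effect already at smaller amounts
- compound 2 `COc1ccc(-c2c(Br)c(=O)c3c(OC)cc(OC)cc3n2S(=O)(=O)c2ccc(OC)cc2)cc1`: 2920 nM
- compound 3 `COc1ccc(-c2cc(=O)c3c(OC)cc(OC)cc3n2S(=O)(=O)c2ccc(C)c([N+](=O)[O-])c2)cc1`: > 51700 nM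

Compound 3 stands at a limit of this assay rather than at a number: its value the limit of > 51700 nM in this assay, at which 1 of the 3 values shown sits, is a cut-off the measurement did not get past. Going by the values given here, compound 1 also sits at a limit, (the limit of > 34400 nM in this assay, at which 1 of the 3 values shown sits), so of the three measured compounds only compound 2 gives an actual number, and compound 2 carries a bromine and a different sulfonyl aryl group, so no single-change step links it to compound 3 or compound 1.

Compound 4 `COc1ccc(-c2cc(=O)c3c(OC)cc(OC)cc3n2S(=O)(=O)c2cc(Cl)cc(Cl)c2O)cc1` is not yet measured. It differs from compound 3 in one place: 3,5-dichloro-2-hydroxyphenyl in place of 4-methyl-3-nitrophenyl on a sulfonyl sulfur. The phenolic hydroxyl and the two chlorines replace the methyl and the nitro group on the ring attached to the sulfonyl sulfur.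

Among the compounds with values here, with compound 3 at a limit, only a floor is known for the starting point, and no measured step shows what a change on this sulfonyl aryl ring does. The expectation for the step from compound 3 to compound 4 is therefore open in direction, with weak activity the likelier outcome; the expected step is an at least 1.7-fold lower number from compound 3 to compound 4 (0.23 log units; that floor lies within the scatter). Compound 4 is estimated at 30000 nM, with a range from 4000 nM to 100000 nM.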

Compound 4, half-maximal effective concentration: > 37900 nM
Compound 4: no number, only a limit; the forecaster's own chance of this, stated with the estimate: 50%; middle value at least 1.2-fold (0.10 log units) away from the limit.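

Compound 3 and compound 4 both stand at limits of this assay rather than at numbers, so the swap of 4-methyl-3-nitrophenyl for 3,5-dichloro-2-hydroxyphenyl cannot be read as a step in either direction. The compounds shown leave open whether any change to this sulfonyl aryl ring alone can shift activity in this assay.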